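A few compounds are considered here, and "the series" means these few. Any claim that something is new, unique, unknown or untested is made for them only; others in the source may bear on it.

In a functional assay on KYSE-70 cells for antiproliferative activity against KYSE-70 cell line (Homo sapiens), read by MTT assay, with a stated time of 72 h (a higher number here means a weaker inhibitor, a lower number a stronger inhibitor), the measured compounds read as follows:

compound 1 `O=C(Nc1cccc(F)c1)c1cc(=O)[nH]c2cc(Br)ccc12` gives 8900 nM
compound 2 `O=C(Nc1cccc(C(F)(F)F)c1)c1cc(=O)[nH]c2cc(Br)ccc12` gives > 20000 nM, a limit of the assay and not a number
compound 3 `O=C(Nc1cccc(F)c1)c1cc(=O)[nH]c2cc(-c3ccc(F)cc3)ccc12` gives 3300 nM

Among the two true numbers, compound 3 has the lower one, and compound 1 stands nearest at 8900 nM in this assay. Compound 4 `O=C(Nc1cccc(F)c1)c1cc(=O)[nH]c2cc(-c3cccc(F)c3)ccc12` has the same atoms as compound 3, joined differently: 3-fluorophenyl in place of 4-fluorophenyl on an aromatic carbon, with 3-fluorophenyl in place of 4-fluorophenyl on an aromatic carbon.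

Two measured steps give a sense of size. One is a 2.7-fold lower number from compound 1 to compound 3 (0.43 log units; beyond the scatter), with 4-fluorophenyl in place of bromo. The other is an at least 2.2-fold higher number from compound 1 to compound 2 (0.35 log units; beyond the scatter), with trifluoromethyl in place of fluoro. Neither moves a fluorine around a ring, so they guide only loosely. Compound 4 keeps the same group type as compound 3, so the expected change is small, an estimated 1.1-fold higher number from compound 3 to compound 4 (0.03 log units; within the scatter), with no shift beyond the scatter expected. For compound 4 the estimated value is 3500 nM, with an expected range of 1500 nM to 8000 nM.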

Compound 4, half-maximal inhibitory concentration: 12000 nM
Compound 4: the middle estimate sits 3.4-fold (0.54 log units) below what was measured; the measured number lies above the stated range.
By their numbers in this assay, from the lowest: compound 3; then compounds 1 and 4 (each within the scatter of the next). At a limit, above all of these: compound 2.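

Moving the fluorine on the phenyl ring matters at this position, even though the atoms stay the same: in this assay there is a 3.6-fold higher number from compound 3 to compound 4 (0.56 log units; beyond the scatter). So replacing bromo with a fluorophenyl group does not help in every case, since 3-fluorophenyl gives a 1.3-fold higher number from compound 1 to compound 4 (0.13 log units; within the scatter), unlike 4-fluorophenyl. Nothing measured here accounts for the difference between the two fluorophenyl groups. The compounds shown leave open how an amine or a carboxylic acid on that phenyl ring would read, and whether a longer chain could replace the ring.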